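Swapping a cyclohexyl for a but-3-en-1-yl chain

This account rests on a few compounds, and the source may have more. Where it says the series, first, only, none or still open, it means among the compounds named here.

Measured compounds:
- compound 1 `C[C@H]1CC(Cl)=C([Si](C)(C)C)[C@@H](C2CCCCC2)O1`: 15000 nM
- compound 2 `C[Si](C)(C)C1=C(Cl)C[C@H](C2CCCCC2)O[C@@H]1C1CCCCC1`: 30000 nM
- compound 3 `C[C@@H]1O[C@H](C2CCCCC2)C([Si](C)(C)C)=C(Cl)[C@H]1C`: 42000 nM

All three compounds were tested in a functional assay on WiDr cells (Homo sapiens) for antiproliferative activity; on this read-out lower numbers stand for stronger inhibition of growth and higher numbers for weaker inhibition of growth. Compound 3 shows the highest number of the three: its step from compound 1 is a 2.8-fold higher number from compound 1 to compound 3 (0.45 log units; beyond the scatter), while its distance from compound 2 is within the scatter, so compound 2 and compound 3 cannot be told apart on these numbers.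

Compound 4 `C=CCC[C@H]1O[C@@H](C)[C@H](C)C(Cl)=C1[Si](C)(C)C` differs from compound 3 in one place: but-3-en-1-yl in place of cyclohexyl on a saturated ring carbon. Among the measured compounds shown here, no measured step directly concerns removing a cyclohexyl group. For the measured compounds named here, the only step involving that group, a 2.0-fold higher number from compound 1 to compound 2 (0.30 log units; within the scatter), is within the scatter, which suggests this position is not very sensitive. The step from compound 1 to compound 3 involves a different position and does not bear on the present change.

Compound 4 is therefore expected to land close to compound 3 in this assay, with a step of about a 1.1-fold higher number from compound 3 to compound 4 (0.03 log units; within the scatter). The estimate for compound 4 is 45000 nM, within a range of 15000 nM to 130000 nM.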

Compound 4, concentration for 50% growth inhibition: 37000 nM
The estimate for compound 4 lay 1.2-fold (0.09 log units) above the measured number, and the stated range covers the measured number.
By their numbers in this assay, from the lowest: compounds 1, 2, 4 and 3 (each within the scatter of the next, the first and the last beyond it).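

In this assay, exchanging the cyclohexyl ring on the saturated ring carbon next to the ring oxygen for the open but-3-en-1-yl chain gives a 1.1-fold lower number from compound 3 to compound 4 (0.06 log units; within the scatter) and so cannot be told apart from no change at all. Among the compounds shown here, the earlier compounds showed only a cyclohexyl entering in place of a methyl, with a 2.0-fold higher number from compound 1 to compound 2 (0.30 log units; within the scatter) on a saturated ring carbon; this is the first step in which the cyclohexyl leaves, and it shows that on this scaffold a closed carbon ring can give way to an open chain with a double bond and leave the number where it was. No measured evidence here bears on why the two groups read alike.

As far as these compounds go, whether an amine, a carboxylic acid or a chain longer than but-3-en-1-yl on this carbon would shift the number remains open. Equally open, from the compounds shown here alone, is whether a plain butyl chain would read the same as the but-3-en-1-yl chain.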